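The source may report more compounds than this note shows. Statements on the series, on what has been measured and on what is new or still open speak of the compounds shown alone.

Compound 1 `CN(C)C(=O)c1cc2cnc(Nc3ccc(S(=O)(=O)NCCCCN=C=S)cc3)nc2n1C1CCCC1` and compound 2 `CN(C)C(=O)c1cc2cnc(Nc3ccc(S(=O)(=O)NCCCCCN=C=S)cc3)nc2n1C1CCCC1` share one core and differ only in the length of the chain that ends in a small sulfur-containing group. In a functional assay on A549 cells (Homo sapiens) for inhibition, read by CCK-8 assay, with a stated time of 72 h, tested at 10 uM (a lower number here means a weaker effect, a higher number a stronger effect of the compound at the concentration tested), compound 1 gives 101% and compound 2 gives 102%. The change between them is a group of 4 heavy atoms (2 carbon, 1 nitrogen, 1 sulfur; no ring) in place of a group of 3 heavy atoms (1 carbon, 1 nitrogen, 1 sulfur; no ring), on a saturated chain carbon, four bonds along the chain from a sulfonamide nitrogen and it made a step of a number 1 percentage points higher from compound 1 to compound 2 (within the scatter). Compound 3 `CN(C)C(=O)c1cc2cnc(Nc3ccc(C(=O)NCCCCCCN=C=S)cc3F)nc2n1C1CCCC1` is built on a different core; how that core differs from the core of compound 1 is not broken down here. In this assay compound 3 gives 22.9%. Compound 4 `CN(C)C(=O)c1cc2cnc(Nc3ccc(C(=O)NCCCCCCCN=C=S)cc3F)nc2n1C1CCCC1` is compound 3 with a group of 4 heavy atoms (2 carbon, 1 nitrogen, 1 sulfur; no ring) in place of a group of 3 heavy atoms (1 carbon, 1 nitrogen, 1 sulfur; no ring), on a saturated chain carbon, six bonds along the chain from an amide-type nitrogen. This is the same kind of change as that from compound 1 to compound 2, but the place differs: there it sat four bonds along the chain from a sulfonamide nitrogen, here six bonds along the chain from an amide-type nitrogen. Because a number 1 percentage points higher from compound 1 to compound 2 (within the scatter) lay within the scatter, the step from compound 3 to compound 4 is expected to be about a number 4.1 percentage points higher from compound 3 to compound 4 (within the scatter). Compound 4 is therefore expected to give roughly 27%, estimated to fall between 10% and 50%.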

Compound 4, a percentage reported as inhibition, at one concentration (the size of the read-out at that concentration, not a potency): 12.7%
Compound 4: the middle estimate sits 14.3 percentage points above what was measured, and the stated range covers the measured number.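

On the core of compound 3, the same chain lengthening gave a number 10.2 percentage points lower from compound 3 to compound 4 (beyond the scatter) in this assay. Set beside the step on the core of compound 1, this does not amount to a real difference between the two cores: the same change on two cores in this assay, a number 1 percentage points higher (within the scatter) from compound 1 to compound 2 and a number 10.2 percentage points lower (beyond the scatter) from compound 3 to compound 4, 11.2 percentage points apart, within the scatter of two such steps So there is no sign here that the core changes the effect of lengthening the chain, but with one pair per core this does not prove that the effect is the same on both.

Going by these compounds, it remains open whether a longer chain would bring a further step on either core. On these data alone, it is also open whether a chain ending in an amine or a carboxylic acid, in place of the sulfur-containing end group, would behave alike.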